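Swapping chloro for methoxy on the anilino ring

A few compounds are considered here, and "the series" means these few. Any claim that something is new, unique, unknown or untested is made for them only; others in the source may bear on it.

Compound 1, `C#CCSc1nc(Nc2ccc(OC)cc2)c(C#N)c(-c2ccccc2)n1`, gives 23200 nM in a functional assay on ECa-109 cells (Homo sapiens) for inhibition, read by MTT assay, with a stated time of 72 h; on this read-out lower numbers stand for stronger inhibition and higher numbers for weaker inhibition.
Compound 2, `C#CCSc1nc(Nc2ccccc2Cl)c(C#N)c(-c2ccccc2)n1`, reaches only a limit of this assay, > 128000 nM.
Compound 3, `N#Cc1c(Nc2ccccc2Cl)nc(SCc2cn(Cc3ccccc3Cl)nn2)nc1-c1ccccc1`, gives 28500 nM in this assay.

Among the two numbers shown, compound 3 has the highest, and its value and that of compound 1 lie within the usual scatter of each other; the remaining value, that of compound 2, is a limit rather than a number, as the limit of > 128000 nM in this assay, at which 1 of the 3 values shown sits, records.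

Compound 4, `COc1ccccc1Nc1nc(SCc2cn(Cc3ccccc3Cl)nn2)nc(-c2ccccc2)c1C#N`, differs from compound 3 in one place: methoxy in place of chloro on an aromatic carbon. Read one bond further out, the change is 2-chlorophenyl to 2-methoxyphenyl on the amino group.

Among the measured compounds shown here, one measured step bears on this: an at least 5.5-fold higher number from compound 1 to compound 2 (0.74 log units; beyond the scatter). There the methoxy-bearing compound gave the lower number, though its methoxy sat at a different position of the ring. Taken as a guide, a moderate move to a lower number is expected for compound 4, and the step from compound 3 is estimated as a 2.4-fold lower number from compound 3 to compound 4 (0.38 log units; beyond the scatter). Compound 4 is therefore expected to give about 12000 nM, between 4000 nM and 40000 nM.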

Compound 4, half-maximal inhibitory concentration: 9670 nM
Beside the measured number, compound 4's estimate is 1.2-fold (0.09 log units) above it; the measured number falls inside the stated range.
By their numbers in this assay, from the lowest: compound 4; then compounds 1 and 3 (each within the scatter of the next). At a limit, above all of these: compound 2.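

In this assay, the change from 2-chlorophenyl to 2-methoxyphenyl gives a 2.9-fold lower number from compound 3 to compound 4 (0.47 log units; beyond the scatter), so methoxy in place of chloro can now be read on its own, on the same aromatic carbon, with the rest of the molecule unchanged. The earlier step changed both the group and its place on the ring, and it ended at compound 2, whose value is a limit and not a number: the limit of > 128000 nM in this assay, at which 1 of the 4 values shown sits. Nothing shown explains why the number falls when methoxy replaces chloro.

Going by these compounds, it remains open how an ethoxy group, a hydroxyl or an amine on this carbon would compare with methoxy. On these data alone, it is also open whether the same swap would give a similar step on the side chain that compound 2 carries.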